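Removing the benzyl from compound 3

A few compounds are considered here, and "the series" means these few. Any claim that something is new, unique, unknown or untested is made for them only; others in the source may bear on it.

Compound 3 `C=CCn1ncc2c(C)nc(Cc3ccccc3)n2c1=O` stands at a limit in a functional assay for inhibition, with Homo sapiens as the target; a lower number here means a stronger inhibitor, a higher number a weaker inhibitor. In this assay compound 3 gives > 48000 nM, a limit and not a number. Compound 1 `C=CCn1ncc2c(C)nc(CC)n2c1=O` likewise gives only a limit in this assay, namely > 48000 nM. Compound 2 `C=CCn1ncc2c(Br)nc(Cc3ccccc3)n2c1=O` gives > 48000 nM in this assay, again a limit. Both measured steps into compound 3 are therefore unreadable, a step that the two limits leave unreadable from compound 1 to compound 3 and a step that the two limits leave unreadable from compound 2 to compound 3, since all three values sit at one limit (the limit of > 48000 nM in this assay, at which 3 of the 3 values shown sit). Compound 4 `C=CCn1ncc2c(C)ncn2c1=O` differs from compound 3 by hydrogen in place of benzyl on an aromatic carbon. Going by the values given here, no measured step bears on removal of the benzyl; the measured steps give neither size nor direction, so in this assay no step beyond the scatter is expected and a limit is the likely report again. For compound 4 the estimated value in this assay is 60000 nM, within 20000 nM to 200000 nM. The expected step is a step that the limit leaves unreadable from compound 3 to compound 4.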

Compound 4, half-maximal inhibitory concentration: > 48000 nM
Compound 4: only a limit was reported; the forecaster's own chance of this, stated with the estimate: 85%; the middle value lies beyond the limit too.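

Compound 4 stays at a limit, so the steps into it from compound 1 and compound 3 cannot be read: the limit of > 48000 nM in this assay, at which 4 of the 4 values shown sit.

The compounds shown leave open which change to the shared core, if any, would give a readable value in this assay.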